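A few compounds are considered here, and "the series" means these few. Any claim that something is new, unique, unknown or untested is made for them only; others in the source may bear on it.

Measured in a functional assay on the whole organism (Abdomen) with Mus musculus as the target; a higher number here means that more compound is needed for the effect, a lower number that less compound is needed:
- compound 1 `Cc1nc(Cc2c[nH]cn2)c(C)s1`: > 30 mg/kg, a limit of the assay
- compound 2 `CCc1sc(C)nc1Cc1c[nH]cn1`: 2.3 mg/kg

Going by the values given here, compound 2, at 2.3 mg/kg, holds the only actual number so far. The sole other result, that of compound 1, is a limit of the assay. The next compound is compound 3 `CCc1sc(C(F)(F)F)nc1Cc1c[nH]cn1`, with the change trifluoromethyl in place of methyl on an aromatic carbon. Among the compounds with values here, the only measured step, an at least 13-fold lower number from compound 1 to compound 2 (1.11 log units; beyond the scatter), is large and beyond the scatter. It is a methyl in place of hydrogen on a saturated chain carbon, so it shows that this series can respond sharply to a small change, but it gives neither size nor direction at the aromatic carbon. Within the data shown here, no measured step covers this place. In this assay the expected step is a 1.7-fold higher number from compound 2 to compound 3 (0.24 log units; within the scatter), not beyond the scatter, with wide uncertainty. Compound 3 is estimated at 4 mg/kg, with an expected range of 0.8 mg/kg to 25 mg/kg.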

Compound 3, dose for half-maximal effect: 20.3 mg/kg
Beside the measured number, compound 3's estimate is 5.1-fold (0.71 log units) below it; measured number inside the range.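

The aromatic carbon next to the ring nitrogen and next to the ring sulfur is not a silent position: in this assay, trifluoromethyl in place of methyl gives an 8.8-fold higher number from compound 2 to compound 3 (0.95 log units; beyond the scatter). The series therefore responds at this aromatic carbon as well as at the saturated chain carbon, and here the methyl of the pair is the group that needs less compound for the effect. With a single pair covering this position, the data give a size and a direction but no cause.

Going by these compounds, whether an amine, a methoxy group or a lone chlorine at this carbon would match the methyl of compound 2 remains open. Compound 1 stands at a limit of the assay, and any further upward step from compound 3 could be read only as far as that limit: the limit of > 30 mg/kg in this assay, at which 1 of the 3 values shown sits.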